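This account rests on a few compounds, and the source may have more. Where it says the series, first, only, none or still open, it means among the compounds named here.

Working notes on the series.

Among the compounds with values here, compound 2 `CCCCCCCCCCCCCC(C)S(=O)(=O)NC(=O)Nc1c(C(C)C)cccc1C(C)C` stands at the lower end of the two numbers so far: in an assay on microsomes from liver for inhibition of sterol O-acyltransferase 1 (Rattus norvegicus) (a lower number here means a stronger inhibitor, a higher number a weaker inhibitor), compound 2 gives 830 nM. Within the data shown here, compound 1 `CCCCCCCCC(C)S(=O)(=O)NC(=O)Nc1c(C(C)C)cccc1C(C)C` gives 1300 nM in this assay, and the only measured step, a 1.6-fold lower number from compound 1 to compound 2 (0.19 log units; within the scatter), was a chain lengthening at the far end of the sulfonyl-bearing chain that did not move the number beyond the scatter.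

Compound 3 `CCCCCCCCCCCCCCCCC(C)S(=O)(=O)NC(=O)Nc1c(C(C)C)cccc1C(C)C` is yet to be measured in this assay. The change from compound 2 is propyl in place of hydrogen on a saturated chain carbon, ten or more bonds along the chain from a sulfonyl sulfur, that is, a further lengthening of the same chain, one bond beyond the position lengthened in the step from compound 1. Among the measured compounds shown here, the one step that bears on it, a 1.6-fold lower number from compound 1 to compound 2 (0.19 log units; within the scatter), was small, so no step beyond the scatter is expected for compound 3, with at most a slight lean toward a lower number. For compound 3 the expected step is a 1.3-fold lower number from compound 2 to compound 3 (0.11 log units; within the scatter), giving an estimate of 650 nM with a range of 250 nM to 1700 nM.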

Compound 3, half-maximal inhibitory concentration: 1390 nM
Compound 3: middle estimate off by 2.1-fold (0.33 log units), on the low side; the measured number falls inside the stated range.
By their numbers in this assay, from the lowest: compounds 2, 1 and 3 (each within the scatter of the next).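

Adding propyl in place of hydrogen on a saturated chain carbon gives (a 1.7-fold higher number from compound 2 to compound 3 (0.22 log units; within the scatter)), and the octyl difference measured from the shorter chain gives (a 1.1-fold higher number from compound 1 to compound 3 (0.03 log units; within the scatter)). Across the three chain lengths shown, this assay therefore separates none of the compounds beyond the scatter, and the small step seen with the first lengthening is not continued in the same direction by this further lengthening. Nothing measured bears on why the numbers stay so close.

Still open, on these data alone, is whether a different group at the far end of this chain, such as a carboxylic acid or an amine, would give a step beyond the scatter. A chain shorter than that of compound 1 is also untested by the compounds shown, so the lower limit of this flat stretch remains unknown.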